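The compounds below may be only part of what the source reports. "The series", "measured", "known", "first", "only" and "open" are said of these compounds alone.

Compound 1 `O=C(/C=C/c1ccccc1)N[C@@H](CCCCCC(=O)NO)C(=O)NCc1ccccc1` carries a hydroxamic acid at the end of a chain, and in a functional assay on NFF cells (Homo sapiens) for antiproliferative activity (on this read-out higher numbers stand for weaker inhibition and lower numbers for stronger inhibition), compound 1 gives 4010 nM. Two changes to it have been tried separately.

Compound 2 `O=C(CCCCC[C@H](NC(=O)c1ccc(C(F)(F)F)cc1)C(=O)NCc1ccccc1)NO` differs from compound 1 by 4-(trifluoromethyl)phenyl in place of 2-phenylethenyl on a carbonyl carbon. The result is a 2.5-fold lower number from compound 1 to compound 2 (0.40 log units; beyond the scatter), and in this assay compound 2 gives 1610 nM.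

Compound 3 `O=C(/C=C/c1ccccc1)N[C@@H](CCCCCC(=O)NO)C(=O)Nc1cccc2cccnc12` differs from compound 1 at the other end of the molecule, by quinolin-8-yl in place of benzyl on an amide-type nitrogen. Here the result is a 3.2-fold lower number from compound 1 to compound 3 (0.51 log units; beyond the scatter), and in this assay compound 3 gives 1240 nM. Compound 3 and compound 2 lie within the usual scatter of each other, so their numbers cannot be told apart.

Compound 4 `O=C(CCCCC[C@H](NC(=O)c1ccc(C(F)(F)F)cc1)C(=O)Nc1cccc2cccnc12)NO` brings the two changes together. It differs from compound 3 by 4-(trifluoromethyl)phenyl in place of 2-phenylethenyl on a carbonyl carbon, which is the same change that turns compound 1 into compound 2, made on the same kind of carbonyl carbon, with the core of compound 3 rather than that of compound 1 underneath. Going by the values given here, with only one earlier example of this change, the expectation rests on it alone. The step from compound 3 to compound 4 is estimated as a 2.3-fold lower number from compound 3 to compound 4 (0.35 log units; beyond the scatter), set beside a 2.5-fold lower number from compound 1 to compound 2 (0.40 log units; beyond the scatter), because the change gave a 2.5-fold lower number from compound 1 to compound 2 (0.40 log units; beyond the scatter) on the related core. On that basis compound 4 is expected to give about 550 nM, somewhere between 250 nM and 1400 nM.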

Compound 4, half-maximal inhibitory concentration: 696 nM
The estimate for compound 4 lay 1.3-fold (0.10 log units) below the measured number; the measured number falls inside the stated range.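

In this assay the change to 4-(trifluoromethyl)phenyl gives a 1.8-fold lower number from compound 3 to compound 4 (0.25 log units; within the scatter) on the core carrying quinolin-8-yl, a step too small on its own to separate from ordinary assay variation, but it does not differ from the earlier step on the core carrying benzyl: the same change on two cores in this assay, a 2.5-fold lower number (0.40 log units; beyond the scatter) from compound 1 to compound 2 and a 1.8-fold lower number (0.25 log units; within the scatter) from compound 3 to compound 4, 1.4-fold (0.15 log units) apart, within the scatter of two such steps.

The other change, to quinolin-8-yl, gives a 2.3-fold lower number from compound 2 to compound 4 (0.36 log units; beyond the scatter) on the core carrying 4-(trifluoromethyl)phenyl, and it too matches its earlier step: the same change on two cores in this assay, a 3.2-fold lower number (0.51 log units; beyond the scatter) from compound 1 to compound 3 and a 2.3-fold lower number (0.36 log units; beyond the scatter) from compound 2 to compound 4, 1.4-fold (0.15 log units) apart, within the scatter of two such steps.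

So in these four compounds each change behaved much the same on both cores, and the two changes together worked roughly as the sum of their separate steps, but two cores per change are a very small sample, and this does not show that either change would carry over to other cores or explain how either one acts.

On these data alone, it remains open whether the same agreement would hold with a longer chain ahead of the hydroxamic acid, or with a carboxylic acid in its place. As far as these compounds go, it is also open whether a nitrile in place of trifluoromethyl would give a step of similar size on both cores.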